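A Methoxy for Fluoro Swap on the Benzylamine Arm

A few compounds are considered here, and "the series" means these few. Any claim that something is new, unique, unknown or untested is made for them only; others in the source may bear on it.

Compound 3 `Nc1cc(N)c2nc(-c3ccccc3)c(NCc3ccc(F)cc3)nc2c1` carries a 4-fluorophenyl group. In a functional assay on IGROV-1 cells (Homo sapiens) for inhibition, read by sulforhodamine B assay, with a stated time of 48 h (on this read-out higher numbers stand for weaker inhibition of growth and lower numbers for stronger inhibition of growth), compound 3 gives only a limit, < 100000 nM. Its companions on the shared core are compound 1 `Nc1cc(N)c2nc(-c3ccccc3)c(NCc3ccc(Cl)c(Cl)c3)nc2c1`, which gives 5890 nM, and compound 2 `COc1ccc(CNc2nc3cc(N)cc(N)c3nc2-c2ccccc2)cc1OC`, which gives 40700 nM. The step of a 6.9-fold higher number from compound 1 to compound 2 (0.84 log units; beyond the scatter) is the only readable one; the steps a step that the limit leaves unreadable from compound 1 to compound 3 and a step that the limit leaves unreadable from compound 2 to compound 3 are left unreadable by the limit (the limit of < 100000 nM in this assay, at which 1 of the 3 values shown sits). Compound 4 `COc1ccc(CNc2nc3cc(N)cc(N)c3nc2-c2ccccc2)cc1` differs from compound 3 by methoxy in place of fluoro on an aromatic carbon. Within the data shown here, no measured step bears directly on a 4-methoxyphenyl group; the nearest guide is compound 2 with its 3,4-dimethoxyphenyl at 40700 nM. A step that the limit leaves unreadable from compound 3 to compound 4 is therefore expected. Compound 4 is estimated at 40000 nM, within 10000 nM to 100000 nM.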

Compound 4, concentration for total growth inhibition: 26900 nM
Estimate against measurement, compound 4: 1.5-fold (0.17 log units) above, within the range that was stated.
By their numbers in this assay, from the lowest: compound 1; then compounds 4 and 2 (each within the scatter of the next).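

In this assay, the 4-methoxyphenyl group of compound 4 and the 3,4-dimethoxyphenyl group of compound 2 cannot be told apart, with a 1.5-fold lower number from compound 2 to compound 4 (0.18 log units; within the scatter). The 3,4-dichlorophenyl group of compound 1 keeps its lead over the single methoxy as well, with a 4.6-fold higher number from compound 1 to compound 4 (0.66 log units; beyond the scatter). The step from compound 3 cannot be read, because compound 3 gives only a limit: the limit of < 100000 nM in this assay, at which 1 of the 4 values shown sits.

The compounds shown leave open how a 4-chlorophenyl group, with a single chlorine, would compare with compound 1 and compound 4. They also leave open how an amine or a carboxylic acid on this ring would read.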